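Adding One Methyl to the Chain of Compound 3

A few compounds are considered here, and "the series" means these few. Any claim that something is new, unique, unknown or untested is made for them only; others in the source may bear on it.

Within the data shown here, in a physicochemical assay for lipophilicity (on this read-out higher numbers stand for higher lipophilicity and lower numbers for lower lipophilicity), compound 3 (`C#CC(CC)OC[n+]1ccn(C)c1/C=N/O`) gives -1.49 and stands second highest of the three numbers so far, with compound 1 (`C=CC(CCC)OC[n+]1ccn(C)c1/C=N/O`) higher at -0.87 and compound 2 (`C#CC(C)OC[n+]1ccn(C)c1/C=N/O`) lower at -2.14 in the same series. Compound 4 (`C#CC(CCC)OC[n+]1ccn(C)c1/C=N/O`) differs from compound 3 by one change (methyl in place of hydrogen on a saturated chain carbon, three bonds along the chain from an oxygen on a saturated carbon and a triple-bonded carbon), which turns ethyl to propyl. Among the measured compounds shown here, one measured step bears on it: a number 0.65 log units higher from compound 2 to compound 3 (beyond the scatter) is the same replacement at two bonds along the chain, modest and beyond the scatter. For the measured compounds named here, a similar upward move is expected, estimated as a number 0.54 log units higher from compound 3 to compound 4 (beyond the scatter) in this assay with only that step to go on. Compound 4 is estimated at -0.95 (range -1.25 to -0.65).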

Compound 4, distribution coefficient: -1.1
Compound 4: middle estimate off by 0.15 log units, on the high side; low and high end bracket the measured number.
By their numbers in this assay, from the lowest: compound 2; then compound 3; then compounds 4 and 1 (each within the scatter of the next).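

On this assay, lengthening the chain from ethyl to propyl still moves the number upward (a number 0.39 log units higher from compound 3 to compound 4 (beyond the scatter)), so the rise seen from methyl to ethyl carries one carbon further out. Over both extensions together the change is larger (a number 1.04 log units higher from compound 2 to compound 4 (beyond the scatter)), while ethynyl in place of vinyl with the propyl chain kept gives only a difference that the scatter covers (a number 0.23 log units lower from compound 1 to compound 4 (within the scatter)). Nothing on hand accounts for either result. From the compounds shown here alone, whether a butyl chain would raise the number again, or an amine on this chain would move it, remains open.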